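The source may hold more compounds than are shown below. What is called first, only, known or untested is meant among the compounds shown, and "the series" means these compounds.

Two measured members of the series share one core. Going by the values given here, compound 1 `COc1ccc(NC(=O)Nc2nnc(Sc3ncnc4scc(-c5ccncc5)c34)s2)cc1` gives 16900 nM in a functional assay on HUVEC cells (Homo sapiens) for antiproliferative activity, read by MTT assay, with a stated time of 48 h (a lower number here means a stronger inhibitor, a higher number a weaker inhibitor), the highest of the two numbers so far, so compound 1 is the weaker inhibitor of the pair. Compound 2 `O=C(Nc1ccc(Cl)c(Cl)c1)Nc1nnc(Sc2ncnc3scc(-c4ccncc4)c23)s1` gives 7800 nM in this assay. Among the compounds with values here, the single measured step, a 2.2-fold lower number from compound 1 to compound 2 (0.34 log units; beyond the scatter), is the only guide available here.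

Compound 3 `O=C(Nc1cccc(F)c1)Nc1nnc(Sc2ncnc3scc(-c4ccncc4)c23)s1` has not yet been measured; it differs from compound 1 by 3-fluorophenyl in place of 4-methoxyphenyl on an amide-type nitrogen. Within the data shown here, the one comparison that bears on this change is a 2.2-fold lower number from compound 1 to compound 2 (0.34 log units; beyond the scatter), in which a halogenated phenyl also replaced the 4-methoxyphenyl and the number fell modestly. A step in the same direction is expected for compound 3, a 1.5-fold lower number from compound 1 to compound 3 (0.19 log units; within the scatter), likely at or within the edge of the scatter, because a 2.2-fold lower number from compound 1 to compound 2 (0.34 log units; beyond the scatter) was itself only modest. Compound 3 is therefore expected to give 11000 nM, with a range from 5500 nM to 22000 nM.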

Compound 3, half-maximal inhibitory concentration: 13700 nM
Compound 3: middle estimate off by 1.2-fold (0.10 log units), on the low side, within the range that was stated.
By their numbers in this assay, from the lowest: compounds 2, 3 and 1 (each within the scatter of the next, the first and the last beyond it).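

On the amide-type nitrogen, in this assay the change from 4-methoxyphenyl to 3-fluorophenyl reads as a 1.2-fold lower number from compound 1 to compound 3 (0.09 log units; within the scatter) and does not separate these two compounds. The change from 3,4-dichlorophenyl to 3-fluorophenyl reads as a 1.8-fold higher number from compound 2 to compound 3 (0.24 log units; within the scatter) and does not separate those two either, so compound 3 cannot be assigned to either side of the gap between compound 1 and compound 2. No measurement shown here offers an explanation for these steps.

Still open, from the compounds shown here alone, is whether 3-chlorophenyl on this nitrogen would read with compound 2 or with compound 3. Also open, going by these compounds, is how the number would respond to a phenyl carrying an amine or a carboxylic acid, or to cyclohexyl in place of the phenyl.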